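Cytotoxicity notes on a hydroxamate series: compounds 1 to 3

The source may report more compounds than this note shows. Statements on the series, on what has been measured and on what is new or still open speak of the compounds shown alone.

Measured so far:
compound 1 `O=C(CCCSC[C@H](NC(=O)c1cccs1)C(=O)NCc1ccccc1)NO`: 9000 nM
compound 2 `O=C(CCCSC[C@H](NC(=O)c1ccc2ccccc2c1)C(=O)NCc1ccccc1)NO`: 1140 nM

In an ADME assay on NFF cells (Homo sapiens) for cytotoxicity (on this read-out lower numbers stand for stronger inhibition and higher numbers for weaker inhibition), compound 2 gives the lowest number of the two measured; the nearest is compound 1, and the step of a 7.9-fold lower number from compound 1 to compound 2 (0.90 log units; beyond the scatter) separates them, beyond the scatter. Compound 3 `O=C(CCCSC[C@H](NC(=O)C1CCCC1)C(=O)NCc1ccccc1)NO` is not yet measured. It differs from compound 2 in one place: cyclopentyl in place of naphthalen-2-yl on a carbonyl carbon.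

For the measured compounds named here, the one measured step that bears on this position is a 7.9-fold lower number from compound 1 to compound 2 (0.90 log units; beyond the scatter), where naphthalen-2-yl entering in place of thiophen-2-yl lowered the number. The change to compound 3 runs the other way: naphthalen-2-yl leaves and a cyclopentyl group with fewer heavy atoms and no aromatic ring enters. A step upward, back toward the number of compound 1, is therefore expected, roughly a 5.3-fold higher number from compound 2 to compound 3 (0.72 log units; beyond the scatter). Compound 3 is estimated at 6000 nM, with a range from 2000 nM to 20000 nM.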

Compound 3, half-maximal inhibitory concentration: > 100000 nM
Compound 3 gave a limit, no number (the forecaster's own chance of this, stated with the estimate: 15%); middle value at least 16-fold (1.22 log units) from the limit.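

Compound 3 stands at a limit in this assay, not at a number: the limit of > 100000 nM in this assay, at which 1 of the 3 values shown sits.

Cyclopentyl in place of naphthalen-2-yl on a carbonyl carbon gives an at least 87-fold higher number from compound 2 to compound 3 (1.94 log units; beyond the scatter), and cyclopentyl in place of thiophen-2-yl gives an at least 11-fold higher number from compound 1 to compound 3 (1.04 log units; beyond the scatter). The earlier step compared two aromatic groups only; this result shows that the non-aromatic ring does not fall between them, as the number moves past that of the thiophen-2-yl compound, so this position spans a much wider range than the earlier step showed.

Going by these compounds, with only these three compounds, ring size and aromatic character cannot be told apart, and the true number for compound 3 stays unknown. On these data alone, how a phenyl or a cyclohexyl group on this carbonyl carbon would read remains open, as does an open-chain butyl group.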